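Chloro for fluoro in the bromophenyl series

The compounds below may be only part of what the source reports. "The series", "measured", "known", "first", "only" and "open" are said of these compounds alone.

- compound 1 `Nc1nc(NCCNc2ncc(-c3ncc[nH]3)c(-c3ccc(F)cc3C(F)(F)F)n2)ccc1[N+](=O)[O-]`: > 0.5 h (a limit)
- compound 2 `Nc1nc(NCCNc2ncc(-c3ncc[nH]3)c(-c3ccc(Br)cc3F)n2)ccc1[N+](=O)[O-]`: > 0.5 h (a limit)

In an ADME assay on microsomes from liver (Canis lupus familiaris) for metabolic stability (a higher number here means that the compound lasts longer, a lower number that the compound disappears faster), compound 2 gives > 0.5 h, which is a limit of the assay and not a number. Compound 1 gives > 0.5 h, which is also a limit. The position of compound 2 therefore rests on one shared reading: the limit of > 0.5 h in this assay, at which 2 of the 2 values shown sit.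

The next structure is compound 3 `Nc1nc(NCCNc2ncc(-c3ncc[nH]3)c(-c3ccc(Br)cc3Cl)n2)ccc1[N+](=O)[O-]`. The change is chloro in place of fluoro on an aromatic carbon, ortho to a large group and meta to a bromo group.

Going by the values given here, only one measured step bears on this change, since it also concerns the substituted phenyl group: a step that the two limits leave unreadable from compound 1 to compound 2. Its size cannot be read, so it gives no basis for predicting a direction. No step beyond the scatter is expected in this assay, and a further limit is the likely report. The estimated change is a step that the limit leaves unreadable from compound 2 to compound 3. Compound 3 is expected at 0.6 h, with an estimated range of 0.35 h to 1.2 h.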

Compound 3, half-life: > 0.5 h
Compound 3 was reported as a limit (the forecaster's own chance of this, stated with the estimate: 70%); the middle value is on the limit's open side.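

No step can be read from compound 3 in this assay: its steps from compound 1 and compound 2 are unreadable, since all three results are limits of the assay: the limit of > 0.5 h in this assay, at which 3 of the 3 values shown sit.

The compounds shown leave open whether 4-bromo-2-chlorophenyl, 4-bromo-2-fluorophenyl and 4-fluoro-2-(trifluoromethyl)phenyl differ at all in this assay.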